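The source may hold more compounds than are shown below. What is called first, only, known or untested is meant among the compounds shown, and "the series" means these compounds.

Measured in an assay on HEK293 cells for displacement of a labelled ligand from NPC1-like intracellular cholesterol transporter 1 (Homo sapiens); on this read-out higher numbers stand for weaker inhibition and lower numbers for stronger inhibition:

compound 1, `CC(C)(C)OC(=O)NCC1CCCN(C(=O)CN2CN(c3ccccc3)C3(CCN(C(=O)c4ccc(C5CCCCC5)cc4)CC3)C2=O)C1`, gives 3800 nM
compound 2, `CC(C)(C)c1ccc(C(=O)N2CCC3(CC2)C(=O)N(CC(=O)NCCC(=O)O)CN3c2ccccc2)cc1`, gives 11400 nM
compound 3, `CC(C)(C)c1ccc(C(=O)N2CCC3(CC2)C(=O)N(CC(=O)NCNS(C)(=O)=O)CN3c2ccccc2)cc1`, gives 3200 nM

Compound 1 stands second highest of these three numbers. Its number and that of compound 3 lie within the usual scatter of each other, so nothing separates them; compound 2 gives a higher number than compound 1, beyond the scatter. Among the compounds with values here, the one step in the set, a 3.6-fold lower number from compound 2 to compound 3 (0.55 log units; beyond the scatter), concerns a group on the chain that hangs from the amide-type nitrogen, and shows that an exchange at that end of the molecule can move the number modestly.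

Compound 4, `CCC1CCCN(C(=O)CN2CN(c3ccccc3)C3(CCN(C(=O)c4ccc(C5CCCCC5)cc4)CC3)C2=O)C1`, differs from compound 1 at the other end, on the piperidine-bearing side: methyl in place of (tert-butoxycarbonyl)amino on a saturated chain carbon bound to a saturated ring carbon. Within the data shown here, no measured pair changes this position, so the step from compound 2 to compound 3 is only a loose guide to how far such a swap might reach. A large group that can donate and accept hydrogen bonds gives way to a single carbon, and without a measured precedent the safest expectation is that compound 1 and compound 4 will differ by little, so compound 4 is expected to give about 4500 nM, with a likely range from 1500 nM to 14000 nM in this assay. This estimate means a 1.2-fold higher number from compound 1 to compound 4 (0.07 log units; within the scatter), expected to sit within the scatter.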

Compound 4, half-maximal inhibitory concentration: 2600 nM
For compound 4 the middle estimate is 1.7-fold (0.24 log units) above the measured one; the range from low to high includes it.
By their numbers in this assay, from the lowest: compounds 4, 3 and 1 (each within the scatter of the next); then compound 2.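

In this assay, within the data shown here, replacing (tert-butoxycarbonyl)amino with methyl on a saturated chain carbon bound to a saturated ring carbon gives a 1.5-fold lower number from compound 1 to compound 4 (0.16 log units; within the scatter), the first reading at this position. A group of 8 heavy atoms, with 1 hydrogen-bond donor and 2 hydrogen-bond acceptors, gives way to a single carbon with neither, and the two numbers cannot be told apart, whereas the step at the other end of the molecule, a 3.6-fold lower number from compound 2 to compound 3 (0.55 log units; beyond the scatter), does stand clear of the usual scatter. Nothing at hand explains why this large exchange leaves the number within the scatter.

This single pair says nothing about whether other groups at this place, such as an amine, a carboxylic acid or a longer chain, would give a number beyond the scatter of compound 1. It also leaves open whether the same exchange would read alike on a molecule built like compound 3, which carries a different group on its benzoyl end and a different chain on the amide-type nitrogen.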